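This account rests on a few compounds, and the source may have more. Where it says the series, first, only, none or still open, it means among the compounds named here.

In an ADME assay on Vero cells (Chlorocebus sabaeus) for cytotoxicity, read by MTT assay, with a stated time of 48 h (on this read-out lower numbers stand for stronger inhibition and higher numbers for weaker inhibition), compound 2 `O=c1cc(N2CCN(CC3CCC(NS(=O)(=O)c4ccccc4)CC3)CC2)sc2c([N+](=O)[O-])cc(C(F)(F)F)cc12` gives > 64 ug/mL, and this is a limit of the assay, not a number. Compound 1 `Cc1cccc(C(=O)OC2CCC(CN3CCN(c4cc(=O)c5cc(C(F)(F)F)cc([N+](=O)[O-])c5s4)CC3)CC2)c1` gives > 64 ug/mL, which is also a limit. The whole picture so far is therefore (the limit of > 64 ug/mL in this assay, at which 2 of the 2 values shown sit). Among the measured compounds shown here, the only measured step is a step that the two limits leave unreadable from compound 1 to compound 2, in which (phenylsulfonyl)amino takes the place of ((3-methylphenyl)carbonyl)oxy on a saturated ring carbon, so it offers no size to carry forward.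

The next structure is compound 3 `COc1ccccc1C(=O)OC1CCC(CN2CCN(c3cc(=O)c4cc(C(F)(F)F)cc([N+](=O)[O-])c4s3)CC2)CC1`, which differs from compound 2 as follows: ((2-methoxyphenyl)carbonyl)oxy in place of (phenylsulfonyl)amino on a saturated ring carbon. In words, ((2-methoxyphenyl)carbonyl)oxy stands in place of (phenylsulfonyl)amino on a saturated ring carbon. This entering group is close in name and counted make-up to the ((3-methylphenyl)carbonyl)oxy of compound 1, which reads > 64 ug/mL, so no step beyond the scatter is expected in this assay, and no direction can be named. The expected move is a step that the limit leaves unreadable from compound 2 to compound 3, and another limit is the most likely report. Compound 3 is estimated at 70 ug/mL, with an expected range from 32 ug/mL to 128 ug/mL.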

Compound 3, half-maximal inhibitory concentration: > 64 ug/mL
Compound 3: only a limit was reported; the forecaster's own chance of this, stated with the estimate: 85%; the middle value is on the limit's open side.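

In this assay, among the compounds shown here, compound 3 gives > 64 ug/mL, which is a limit of the assay and not a number, so no step linking compound 1, compound 2 and compound 3 can be read. The compounds shown leave open how these three truly compare and which change, if any, would give a readable number, as all rest on one reading: the limit of > 64 ug/mL in this assay, at which 3 of the 3 values shown sit.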